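A few compounds are considered here, and "the series" means these few. Any claim that something is new, unique, unknown or untested is made for them only; others in the source may bear on it.

Measured in an in vivo ADME assay on the whole organism (Rattus norvegicus); a lower number here means that more of the compound stays in the plasma, a higher number that more of the compound sits outside the plasma:
compound 1 (`NS(=O)(=O)c1ccccc1-c1ccc(C(=O)NCCC(=O)Nc2ccc(Br)cn2)cc1`) gives 5.4 L/kg
compound 2 (`NS(=O)(=O)c1ccccc1-c1ccc(C(=O)NC(CC(=O)Nc2ccc(Br)cn2)C(=O)N2CCCCC2)cc1`) gives 5.9 L/kg
compound 3 (`CN(C)Cc1ccccc1-c1ccc(C(=O)N[C@@H](CC(=O)Nc2ccc(Cl)cn2)C(=O)N2CCCCC2)cc1`) gives 59.2 L/kg

Compound 3 stands highest of the three, with compound 1 and compound 2 both far under it. Compound 4 (`CN(C)Cc1ccccc1-c1ccc(C(=O)N[C@H](CC(=O)Nc2ccc(Cl)cn2)C(=O)N2CCCCC2)cc1`) differs from compound 3 in one place: the two compounds have the same atoms and bonds and differ only in configuration as drawn: 1 of 1 stereo elements differ; a stereocentre at a saturated chain carbon is drawn S in compound 3 and R in compound 4. Going by the values given here, no measured pair differs in configuration alone. Among the compounds with values here, the only measured step, a 1.1-fold higher number from compound 1 to compound 2 (0.04 log units; within the scatter), is a different change, (piperidin-1-yl)carbonyl in place of hydrogen, so it offers only weak guidance. No step beyond the scatter is therefore expected in this assay, and this expectation is uncertain. The expected step is a 1.3-fold lower number from compound 3 to compound 4 (0.12 log units; within the scatter). For compound 4 the estimated value is 45 L/kg (range 18 L/kg to 90 L/kg).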

Compound 4, volume of distribution: 14 L/kg
Compound 4: the middle estimate sits 3.2-fold (0.51 log units) above what was measured; the measured number lies below the stated range.
By their numbers in this assay, from the lowest: compounds 1 and 2 (each within the scatter of the next); then compound 4; then compound 3.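

In this assay, the configuration at this saturated chain carbon alone moves the number, with a 4.2-fold lower number from compound 3 to compound 4 (0.63 log units; beyond the scatter). Going by these compounds alone, the earlier change on this carbon, (piperidin-1-yl)carbonyl in place of hydrogen, gave only a 1.1-fold higher number from compound 1 to compound 2 (0.04 log units; within the scatter), so the step from S to R is the first change here to exceed the scatter. The step can be assigned to the stereocentre because nothing else separates the pair: the fact that compounds 3 and 4 differ only in the configuration as drawn

From the compounds shown here alone, whether the same gap between S and R holds in compounds carrying a carboxylic acid in place of the dimethylaminomethyl group remains open.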